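This account rests on a few compounds, and the source may have more. Where it says the series, first, only, none or still open, it means among the compounds named here.

Of the compounds shown here, three built on one shared core have been tested. Compound 1 `CCc1ccc(CN[C@@H]2C[C@H]3C[C@@H]([C@H]2C)C3(C)C)s1` is one of them; in an ADME assay on MDCK cells (Canis lupus familiaris) for cytotoxicity, read by microscopy, with a stated time of 48 h (a lower number here means that less compound is tolerated, a higher number that more compound is tolerated), compound 1 gives 1560 nM. Compound 2 `C=Cc1ccsc1CN[C@@H]1C[C@H]2C[C@@H]([C@H]1C)C2(C)C` gives 50000 nM, and compound 3 `CCCc1csc(CN[C@@H]2C[C@H]3C[C@@H]([C@H]2C)C3(C)C)c1` gives 12500 nM. Compound 1 thus stands at the lowest number of the three, the least tolerated, its gaps to compound 3 and to compound 2 both beyond the scatter. Compound 4 `C[C@H]1[C@H](NCc2ccc(Cl)s2)C[C@H]2C[C@@H]1C2(C)C` has not yet been measured. It differs from compound 1 by chloro in place of ethyl on an aromatic carbon. Among the measured compounds shown here, no measured pair shows a swap of this kind, so the data give no direct guide. The expected step of a 1.9-fold higher number from compound 1 to compound 4 (0.28 log units; within the scatter) is small, toward a somewhat higher number, and may lie within the scatter. Compound 4 is expected to give about 3000 nM, within a range from 800 nM to 15000 nM.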

Compound 4, minimum cytotoxic concentration: 25000 nM
For compound 4 the middle estimate is 8.3-fold (0.92 log units) below the measured one, and the stated range ends below it.
By their numbers in this assay, from the lowest: compound 1; then compounds 3, 4 and 2 (each within the scatter of the next, the first and the last beyond it).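

In this assay, putting chloro in place of ethyl on this aromatic carbon next to the ring sulfur gives a 16-fold higher number from compound 1 to compound 4 (1.20 log units; beyond the scatter). Among the compounds shown here, this is the first direct view of a single change at this position, and it shows that the one swap is enough to move the tolerated concentration well beyond the scatter. The step is also large for so small a change, with no ring, hydrogen-bond donor, acceptor or net charge entering or leaving. Going by these compounds, whether methyl, bromo or a methoxy group at this position would behave more like ethyl or more like chloro remains open. Nothing measured here gives a reason for the step.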